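A few compounds are considered here, and "the series" means these few. Any claim that something is new, unique, unknown or untested is made for them only; others in the source may bear on it.

Working notes on the series, read in an ADME assay on a cell-free system (plasma, Mus musculus) for metabolic stability, read by LC-MS, tested at 2 uM; a higher number here means that the compound lasts longer, a lower number that the compound disappears faster. Compound 1 `COc1cccc(-c2cn(C(=O)NCCCCc3ccccc3)c(=O)o2)c1` gives > 2 h, which is a limit of the assay and not a number. Within the data shown here, compound 2 `O=C(NCCCCc1ccccc1)n1cc(-c2ccccn2)oc1=O` gives 0.667 h, the only true number so far. The next change leads to compound 3 `O=C(NCCCCc1ccccc1)n1cc(-c2cccnc2)oc1=O`: pyridin-3-yl in place of pyridin-2-yl on an aromatic carbon, with pyridin-3-yl in place of pyridin-2-yl on an aromatic carbon, next to the ring oxygen.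

Among the measured compounds shown here, one measured step bears on this: an at least 2.9-fold lower number from compound 1 to compound 2 (0.47 log units; beyond the scatter), beyond the scatter, with pyridin-2-yl in place of 3-methoxyphenyl on an aromatic carbon. Its true size is open, as it starts from a limit. For the measured compounds named here, no measured step compares pyridin-2-yl with pyridin-3-yl, so it gives only a weak hint of direction. The estimate therefore stays anchored on compound 2 at 0.667 h. A small rise is expected, a 1.5-fold higher number from compound 2 to compound 3 (0.18 log units; within the scatter), which would not clearly exceed the scatter. For compound 3 the estimated half-life is 1 h, with an expected range from 0.4 h to 2.5 h.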

Compound 3, half-life: 1 h
Compound 3: the middle estimate sits on the measured number at the digits printed; the measured number falls inside the stated range.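

In this assay, pyridin-3-yl in place of pyridin-2-yl on this aromatic carbon, next to the ring oxygen, gives a 1.5-fold higher number from compound 2 to compound 3 (0.18 log units; within the scatter), so the two pyridine attachments cannot be told apart at this position. The comparison with 3-methoxyphenyl reads an at least 2.0-fold lower number from compound 1 to compound 3 (0.30 log units; that floor lies within the scatter), whereas the earlier step with pyridin-2-yl reads an at least 2.9-fold lower number from compound 1 to compound 2 (0.47 log units; beyond the scatter), so only the earlier step is clearly beyond the scatter, and even that holds only as a floor. Compound 1 gives > 2 h, which is a limit of the assay and not a number, so the true size of both steps from it stays open: the limit of > 2 h in this assay, at which 1 of the 3 values shown sits.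

Going by these compounds, it remains open whether a plain phenyl or pyridin-4-yl at this carbon would sit with the two pyridines or with 3-methoxyphenyl, and so which part of the 3-methoxyphenyl group matters to the read-out. All three compounds also share the core and the chain ending in phenyl, so the effect of a shorter chain or of an amine on that chain cannot be judged from them.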